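The source may report more compounds than this note shows. Statements on the series, on what has been measured and on what is new or still open speak of the compounds shown alone.

Measured compounds in a functional assay on CHO cells with adenosine receptor A1 (Homo sapiens) as the target, read by cAMP accumulation and immunoassay, with a stated time of 6 min, tested at 0.01 uM; on this read-out lower numbers stand for a stronger effect and higher numbers for a weaker effect at the one concentration tested:
compound 1 `Nc1scc(CN2CCN(c3ccc(Cl)cc3Cl)CC2)c1C(=O)c1ccc(Cl)cc1` — 2%
compound 2 `Nc1scc(CN2CCN(c3ccc([N+](=O)[O-])cc3)CC2)c1C(=O)c1ccc(Cl)cc1` — -12%
compound 3 `Nc1scc(CN2CCN(c3ccccc3C(F)(F)F)CC2)c1C(=O)c1ccc(Cl)cc1` — 0%

Compound 3 stands second highest of the three numbers. Its nearest neighbour is compound 1, the step being a number 2 percentage points lower from compound 1 to compound 3 (within the scatter); its furthest is compound 2, with a number 12 percentage points higher from compound 2 to compound 3 (beyond the scatter). All three compounds share the same core and differ only in the group on the amine nitrogen in the ring, so every measured step bears on the change now considered.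

Compound 4 `Nc1scc(CN2CCN(c3ccc(Cl)c(Cl)c3)CC2)c1C(=O)c1ccc(Cl)cc1` is not yet measured in this assay. It differs from compound 3 as follows: 3,4-dichlorophenyl in place of 2-(trifluoromethyl)phenyl on an amine nitrogen in a ring.

For the measured compounds named here, of the measured steps, the exchange of one halogenated or trifluoromethyl-bearing phenyl for another, a number 2 percentage points lower from compound 1 to compound 3 (within the scatter), lies within the scatter, while only the steps to and from the 4-nitrophenyl compound 2, a number 14 percentage points lower from compound 1 to compound 2 (beyond the scatter) and a number 12 percentage points higher from compound 2 to compound 3 (beyond the scatter), go beyond it. Compound 4 carries a dichlorophenyl, closer in kind to compound 1 than to compound 2, so for compound 4 a step of no change at the digits printed from compound 3 to compound 4 (within the scatter) is expected, that is nothing beyond the scatter. Compound 4 is therefore estimated at 0%, with a range of -12% to 12%.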

Compound 4, a percentage reported as activity, at one concentration (the size of the read-out at that concentration, not a potency): -1.2%
Compound 4: middle estimate off by 1.2 percentage points, on the high side; the measured number falls inside the stated range.
By their numbers in this assay, from the lowest: compound 2; then compounds 4, 3 and 1 (each within the scatter of the next).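

The 3,4-dichlorophenyl group on the amine nitrogen in the ring behaves like the two other halogen- or fluorine-bearing aryl groups in this assay: the exchange with the 2-(trifluoromethyl)phenyl group is a number 1.2 percentage points lower from compound 3 to compound 4 (within the scatter), and the exchange with its 2,4-dichlorophenyl isomer is a number 3.2 percentage points lower from compound 1 to compound 4 (within the scatter), so moving one chlorine leaves no readable mark. The 4-nitrophenyl group remains the only one set apart, with a number 10.8 percentage points higher from compound 2 to compound 4 (beyond the scatter), and this now holds against all three other compounds. No available data bear on why the 4-nitrophenyl group separates or why the other three stay level.

On these data alone, whether that separation is specific to the nitro group stays open; a nitrile or a carboxylic acid on the phenyl would test this. Also open, as far as these compounds go, is how an unsubstituted phenyl or an open alkyl chain in that place would read, and whether compounds 1, 3 and 4 would separate at other concentrations.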